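An Iodo Group on the Phenyl of Compound 2

A few compounds are considered here, and "the series" means these few. Any claim that something is new, unique, unknown or untested is made for them only; others in the source may bear on it.

Three compounds have been measured in a functional assay on A549 cells (Homo sapiens) for antiproliferative activity, read by sulforhodamine B assay, with a stated time of 48 h; a higher number here means a weaker inhibitor of growth, a lower number a stronger inhibitor of growth:
- compound 1 `O=C(NNC(=S)Nc1ccccc1)C1=C(Cl)c2ccccc2CCC1` gives 4880 nM
- compound 2 `ClC1=C(c2nnc(-c3ccccc3)o2)CCCc2ccccc21` gives 2270 nM
- compound 3 `COc1cc(-c2nnc(C3=C(Cl)c4ccccc4CCC3)o2)cc(OC)c1OC` gives 4570 nM

In this assay compound 2 gives 2270 nM. Compound 1 gives 4880 nM. The gap between these two compounds lies beyond the scatter, with compound 2 on the side of stronger growth inhibition. Compound 3 gives 4570 nM. The gap between compound 2 and compound 3 lies within the scatter. So compound 2 is a reasonable starting point, although it is not clearly separated from every other compound in the set.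

The next compound, compound 4 `ClC1=C(c2nnc(-c3cccc(I)c3)o2)CCCc2ccccc21`, is compound 2 with a single change, phenyl to 3-iodophenyl: iodo in place of hydrogen on an aromatic carbon. Iodo takes the place of hydrogen on an aromatic carbon, meta to a large group.

For the measured compounds named here, no measured pair in this set differs in one place alone, so no direct precedent for this change exists. The nearest guide is compound 3, which also carries substituents on that aromatic ring and gives 4570 nM, a value within the scatter of compound 2. A small shift towards stronger inhibition is thought possible, but no change beyond the scatter is expected. The expected step is a 1.3-fold lower number from compound 2 to compound 4 (0.10 log units; within the scatter). For compound 4 the estimated value is 1800 nM, with an expected range from 600 nM to 5000 nM.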

Compound 4, concentration for 50% growth inhibition: 2560 nM
Compound 4: the middle estimate sits 1.4-fold (0.15 log units) below what was measured, within the range that was stated.
By their numbers in this assay, from the lowest: compounds 2, 4, 3 and 1 (each within the scatter of the next, the first and the last beyond it).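

In this assay, for the compounds shown here, the step of a 1.1-fold higher number from compound 2 to compound 4 (0.05 log units; within the scatter), is the first comparison in this set between two compounds that differ in one place. It shows that the value for the phenyl compound and the value for its 3-iodophenyl partner lie within the scatter of each other, so an iodo group on this aromatic carbon, meta to a large group, is accommodated with no measurable consequence in this assay. Compound 1 and compound 3 could not show this, as each differs from compound 2 in more than one place, and no measurement shown here offers any explanation for the closeness of the two values.

As far as these compounds go, one iodo group at one position cannot show whether this holds for substituents in general, and it remains open whether a fluoro group, a chloro group, an amine or a carboxylic acid on the same aromatic carbon would give a value beyond the scatter of compound 2. From the compounds shown here alone, the other carbons of this aromatic ring also remain open, as a single methoxy group on any one of them has no one-place comparison here.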